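Triazole aryl variations: expectation for compound 4

The source may hold more compounds than are shown below. What is called first, only, known or untested is meant among the compounds shown, and "the series" means these compounds.

Measured so far:
compound 1 `Nc1cccc(-c2cn(Cc3cc(C(=O)O)cc(-c4ccccc4C(=O)O)c3)nn2)c1` 72600 nM
compound 2 `O=C(O)c1cc(Cn2cc(-c3ccc(NCc4ccccc4)cc3)nn2)cc(-c2ccccc2C(=O)O)c1` 215000 nM
compound 3 `O=C(O)c1cc(Cn2cc(-c3cccnc3)nn2)cc(-c2ccccc2C(=O)O)c1` 252000 nM

In an assay on cells for inhibition of ubiquitin carboxyl-terminal hydrolase isozyme L5 (Homo sapiens), read by fluorescence, with a stated time of 30 min (on this read-out higher numbers stand for weaker inhibition and lower numbers for stronger inhibition), compound 3 gives the highest of the three numbers. Its nearest neighbour is compound 2, whose number lies within the scatter of that of compound 3, so no order between the two can be read. Compound 1 is the furthest, and the single-point step a 3.5-fold higher number from compound 1 to compound 3 (0.54 log units; beyond the scatter) is beyond the scatter, a modest loss.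

Compound 4 `CC(=O)Nc1ccc(-c2cn(Cc3cc(C(=O)O)cc(-c4ccccc4C(=O)O)c3)nn2)cc1` differs from compound 3 as follows: 4-acetamidophenyl in place of pyridin-3-yl on an aromatic carbon. Among the measured compounds shown here, the one measured step that bears on this is the step from compound 1 to compound 3, where pyridin-3-yl in place of 3-aminophenyl gave a modestly higher number. Compound 4 reverses that direction in kind, restoring a six-membered ring of carbon only that carries a nitrogen substituent, though as 4-acetamidophenyl rather than 3-aminophenyl. Compound 2, with a different nitrogen-substituted phenyl, sits with compound 3 within the scatter, so the gain is not assured. A small downward step is therefore expected, a 1.7-fold lower number from compound 3 to compound 4 (0.23 log units; within the scatter), likely not far beyond the scatter. For compound 4 the estimate in this assay is 150000 nM, with a range from 60000 nM to 400000 nM.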

Compound 4, half-maximal inhibitory concentration: 80900 nM
The estimate for compound 4 lay 1.9-fold (0.27 log units) above the measured number; the measured number falls inside the stated range.
By their numbers in this assay, from the lowest: compounds 1 and 4 (each within the scatter of the next); then compounds 2 and 3 (each within the scatter of the next).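

At this aromatic carbon of the five-membered aromatic ring with 3 nitrogen, 4-acetamidophenyl in place of pyridin-3-yl gives in this assay a 3.1-fold lower number from compound 3 to compound 4 (0.49 log units; beyond the scatter), the first direct step showing that a group at this position can lower the number from that of compound 3. A nitrogen on the phenyl ring does not set the number by itself: acetyl in place of benzyl on that nitrogen gives a 2.7-fold lower number from compound 2 to compound 4 (0.42 log units; beyond the scatter), and compound 2 goes against any rule that nitrogen-substituted phenyl groups all sit on the lower side. The swap of 3-aminophenyl for 4-acetamidophenyl gives a 1.1-fold higher number from compound 1 to compound 4 (0.05 log units; within the scatter), so these two groups cannot be ordered, and two different nitrogen-bearing phenyl groups now stand level, away from compounds 2 and 3.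

No available measurement accounts for any of these steps. Still open, as far as these compounds go, is how much the placement on the phenyl ring and the acetyl group each contribute, which 4-aminophenyl would help to separate, and whether a longer acyl chain or a carboxylic acid on that nitrogen would move the number beyond the level of compounds 1 and 4.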